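A few compounds are considered here, and "the series" means these few. Any claim that something is new, unique, unknown or untested is made for them only; others in the source may bear on it.

Measured so far:
- compound 1, `COc1cc(-c2cc(=O)c3ccc(OCCCCCCCCN4CCCC4)cc3o2)cc(OC)c1OC`: 16.3%
- compound 2, `O=c1cc(-c2ccc(OCc3ccccc3)cc2)oc2cc(OCCCCCCCCN3CCCC3)ccc12`: 10.4%

In an ADME assay on HepG2 cells (Homo sapiens) for cytotoxicity, read by MTT assay, with a stated time of 48 h, tested at 1 uM (a lower number here means a weaker effect, a higher number a stronger effect of the compound at the concentration tested), compound 1 gives 16.3%, and compound 2 gives 10.4% in this assay. The two numbers lie within the scatter of each other, so on the numbers shown compound 2 stands alongside compound 1, with neither set apart from the other. Both compounds carry the same long chain ending in the pyrrolidine ring and the same core.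

Compound 3, `O=c1cc(-c2ccc(-c3ccccc3)cc2)oc2cc(OCCCCCCCCN3CCCC3)ccc12`, has not yet been measured. It differs from compound 2 in one place: phenyl in place of benzyloxy on an aromatic carbon. Among the measured compounds shown here, no step between measured compounds is available to guide the size of this change. Given that both measured numbers sit at a weak level, the step of a number 1.6 percentage points higher from compound 2 to compound 3 (within the scatter) is expected to be small, with no direction beyond the scatter. Compound 3 is therefore estimated to give about 12% in this assay, within a range of 2% to 26%.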

Compound 3, a percentage reported as inhibition, at one concentration (the size of the read-out at that concentration, not a potency): 13.9%
Compound 3: the middle estimate sits 1.9 percentage points below what was measured; the measured number falls inside the stated range.
By their numbers in this assay, from the lowest: compounds 2, 3 and 1 (each within the scatter of the next).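

In this assay, phenyl in place of benzyloxy on an aromatic carbon, para to a large group, gives a number 3.5 percentage points higher from compound 2 to compound 3 (within the scatter) and so removes the benzyloxy group without a step beyond the scatter. The larger exchange at this place, 4-phenylphenyl in place of 3,4,5-trimethoxyphenyl, gives a number 2.4 percentage points lower from compound 1 to compound 3 (within the scatter) and also stays within the scatter, so neither step sets compound 3 apart from the compound it is paired with. Nothing measured bears on why these numbers lie where they do and the steps are left as bare numbers.

Going by these compounds, it remains open whether an amine or a carboxylic acid on this aromatic ring would give a step beyond the scatter. On these data alone, it also remains open whether a shorter chain, or a piperidine ring in place of the pyrrolidine ring, would do so.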